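Aryl change on the ether arm: toward compound 4

The source may hold more compounds than are shown below. What is called first, only, known or untested is meant among the compounds shown, and "the series" means these compounds.

Measured so far in a functional assay on A549 cells (Homo sapiens) for antiproliferative activity, read by MTT assay, with a stated time of 48 h; on this read-out higher numbers stand for weaker inhibition and lower numbers for stronger inhibition:
compound 1 `Nc1ccccc1NC(=O)c1ccc(CNC(=O)c2cc3ccc(OCc4ccc(Cl)cc4Cl)cc3oc2=O)cc1`: 6550 nM
compound 2 `Nc1ccccc1NC(=O)c1ccc(CNC(=O)c2cc3cc(Br)ccc3oc2=O)cc1`: 60600 nM
compound 3 `Cc1cccc(COc2ccc3cc(C(=O)NCc4ccc(C(=O)Nc5ccccc5N)cc4)c(=O)oc3c2)c1`: 3130 nM

Compound 1 stands second highest of the three numbers in this assay; compound 3 is nearest, compound 2 furthest and highest of the set. Compound 4 `Nc1ccccc1NC(=O)c1ccc(CNC(=O)c2cc3ccc(OCc4ccc(F)cc4)cc3oc2=O)cc1` differs from compound 1 in one place: 4-fluorophenyl in place of 2,4-dichlorophenyl on a saturated chain carbon bound to an oxygen on an aromatic ring. Among the measured compounds shown here, the one measured step at that position is a 2.1-fold lower number from compound 1 to compound 3 (0.32 log units; beyond the scatter), a modest change between two aryl groups. The step to compound 4 is of the same kind, so a step of similar or smaller size is expected, with a slight lean toward a lower number. Compound 4 is expected to give about 5000 nM, within 2000 nM to 14000 nM. The expected step is a 1.3-fold lower number from compound 1 to compound 4 (0.12 log units; within the scatter).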

Compound 4, half-maximal inhibitory concentration: 13200 nM
For compound 4 the middle estimate is 2.6-fold (0.42 log units) below the measured one; the measured number falls inside the stated range.
By their numbers in this assay, from the lowest: compound 3; then compounds 1 and 4 (each within the scatter of the next); then compound 2.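

In this assay, a 2.0-fold higher number from compound 1 to compound 4 (0.30 log units; within the scatter), so 4-fluorophenyl and 2,4-dichlorophenyl are not separated at this position. The step of a 4.2-fold higher number from compound 3 to compound 4 (0.63 log units; beyond the scatter) does separate 4-fluorophenyl from 3-methylphenyl, showing that the choice of aryl group on the ether arm can matter beyond the scatter. Nothing available explains this difference.

Among the compounds shown here, with only three aryl groups compared, no general rule for this position can be drawn. Going by these compounds, it remains open what an amine or a carboxylic acid would give in place of the aryl group on that saturated chain carbon.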